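A few compounds are considered here, and "the series" means these few. Any claim that something is new, unique, unknown or untested is made for them only; others in the source may bear on it.

Compound 1, `Cc1cn(C2[Se][C@H](CO)[C@@H](O)[C@@H]2N=[N+]=[N-])c(=O)[nH]c1=O`, was tested in a functional assay on K562 cells (Homo sapiens) for cytotoxicity, read by sulforhodamine B assay; a lower number here means a stronger inhibitor, a higher number a weaker inhibitor; in this assay compound 1 gives > 100000 nM, which is a limit of the assay and not a number. Two close relatives were measured as well. Compound 2, `[N-]=[N+]=N[C@@H]1C(n2cc(F)c(=O)[nH]c2=O)[Se][C@H](CO)[C@H]1O`, gives in this assay > 100000 nM, also a limit. Compound 3, `[N-]=[N+]=N[C@@H]1C(n2cc(I)c(=O)[nH]c2=O)[Se][C@H](CO)[C@H]1O`, gives in this assay > 100000 nM, again a limit. The steps among these three are a step that the two limits leave unreadable from compound 1 to compound 2, a step that the two limits leave unreadable from compound 1 to compound 3 and a step that the two limits leave unreadable from compound 2 to compound 3, since all of them sit at the limit of > 100000 nM in this assay, at which 3 of the 3 values shown sit. Compound 4, `Cc1cn(C2[Se][C@H](CO)[C@@H](O)[C@@H]2O)c(=O)[nH]c1=O`, differs from compound 1 by hydroxy in place of azido on a saturated ring carbon. Within the data shown here, no measured step reports a readable change at this position, and every measured value is a limit, so the expected step is a number no higher from compound 1 to compound 4 (the limit leaves the size open), with no readable change. The estimate for compound 4 in this assay is 100000 nM, within 30000 nM to 300000 nM.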

Compound 4, half-maximal inhibitory concentration: > 100000 nM
Compound 4: a limit, no number; the forecaster's own chance of this, stated with the estimate: 80%; the middle value lies on the limit itself.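

In this assay compound 4 gives > 100000 nM, a limit and not a number. Compound 1 is also a limit, so no step can be read between compound 1 and compound 4. The compounds shown leave open whether any of these changes alters cytotoxicity, because all of them sit at one point: the limit of > 100000 nM in this assay, at which 4 of the 4 values shown sit.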